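A few compounds are considered here, and "the series" means these few. Any claim that something is new, unique, unknown or untested is made for them only; others in the source may bear on it.

Compound 1 `COc1ccc(OC)c(-c2nc(C(c3ccccc3)c3ccccc3)sc2CC(=O)O)c1` gives 80% in an in vitro functional assay on HEK285-7 cells for antagonist activity at prostaglandin D2 receptor 2 (Homo sapiens), read by BRET and beta-arrestin recruitment; on this read-out lower numbers stand for smaller maximal responses and higher numbers for larger maximal responses.
Compound 2 `NS(=O)(=O)c1ccc(-c2nc(C(c3ccc(F)cc3)c3ccc(F)cc3)sc2CC(=O)O)cc1` gives 80% in this assay.

Compound 2 stands level with compound 1 at the digits shown, with no change beyond the scatter of repeated measurements. Compound 3 `O=C(O)Cc1sc(C(c2ccc(F)cc2)c2ccc(F)cc2)nc1-c1cccc(F)c1` has not yet been measured; it differs from compound 2 by 3-fluorophenyl in place of 4-sulfamoylphenyl on an aromatic carbon. For the measured compounds named here, no step between measured compounds is known, and the two measured compounds sit at one level, so in this assay a step of no more than the scatter is expected, in either direction. Compound 3 is therefore estimated at 80%, in a range from 65% to 95%. The expected step of no change at the digits printed from compound 2 to compound 3 (within the scatter) is estimated to lie within the scatter.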

Compound 3, largest response reached (reported as efficacy), in percent of the reference or control that the assay uses: 80%
Compound 3: middle estimate and measured number agree at the digits printed; the range from low to high includes it.
By their numbers in this assay, from the lowest: compounds 1, 2 and 3 (each within the scatter of the next).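

In this assay, 3-fluorophenyl in place of 4-sulfamoylphenyl on this aromatic carbon brings no change at the digits printed from compound 2 to compound 3 (within the scatter). The maximal response at this position therefore holds level whether the group carries a hydrogen-bond donor and acceptors, as 4-sulfamoylphenyl does, or none, as 3-fluorophenyl does. Nothing available gives a reason for this level result. The compounds shown leave open whether any group on this carbon, such as an amine in place of the aromatic ring, would move the response beyond the scatter. They also leave open whether a longer chain in place of the carboxymethyl group would do so.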